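A few compounds are considered here, and "the series" means these few. Any claim that something is new, unique, unknown or untested is made for them only; others in the source may bear on it.

Compound 3 `CS(=O)(=O)c1cccc2c(=O)c(-c3nn[nH]n3)c[nH]c12` gives 10 mg/kg in a functional assay on the whole organism (strain Sprague-Dawley) for inhibition, with Rattus norvegicus as the target (on this read-out higher numbers stand for an effect only at larger amounts of compound and lower numbers for an effect already at smaller amounts), level at the digits shown with compound 2 `CSc1cccc2c(=O)c(-c3nn[nH]n3)c[nH]c12` at 10 mg/kg, the two together the highest of the three numbers; compound 1 `CC(C)c1cccc2c(=O)c(-c3nn[nH]n3)c[nH]c12` gives 1.25 mg/kg. The change to compound 4 `CC(C)Oc1cccc2c(=O)c(-c3nn[nH]n3)c[nH]c12` is isopropoxy in place of methylsulfonyl on an aromatic carbon. Among the compounds with values here, two steps bear on it: an 8.0-fold higher number from compound 1 to compound 3 (0.90 log units; beyond the scatter) and no change at the digits printed from compound 2 to compound 3 (within the scatter). Trading one sulfur group for the other left the number where it was, whereas the isopropyl compound 1 sits clearly lower. Isopropoxy carries three carbons as isopropyl does, so a move part of the way back toward compound 1 is expected, and the expected step is a 4.0-fold lower number from compound 3 to compound 4 (0.60 log units; beyond the scatter). Compound 4 is therefore estimated at 2.5 mg/kg, with a range from 1.25 mg/kg to 5 mg/kg.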

Compound 4, minimum effective dose: 0.078 mg/kg
Compound 4: the middle estimate sits 32-fold (1.51 log units) above what was measured; the measured number lies below the stated range.
By their numbers in this assay, from the lowest: compound 4; then compound 1; then compounds 2 and 3 (each within the scatter of the next).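

In this assay this position proves far more sensitive to the substituent than the two sulfur groups suggested: isopropoxy gives a 130-fold lower number from compound 3 to compound 4 (2.11 log units; beyond the scatter) and a 130-fold lower number from compound 2 to compound 4 (2.11 log units; beyond the scatter) as well. It also goes past the isopropyl group, with a 16-fold lower number from compound 1 to compound 4 (1.20 log units; beyond the scatter) on the shared core. Placing an oxygen between the ring and the isopropyl part is therefore itself a large change at this aromatic carbon.

No supporting measurement accompanies these numbers to explain the step. From the compounds shown here alone, whether methoxy, ethoxy or an amine on this carbon would hold the low number stays open.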